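A few compounds are considered here, and "the series" means these few. Any claim that something is new, unique, unknown or untested is made for them only; others in the source may bear on it.

Measured so far:
- compound 1, `O=C(CCCCCN1C(=O)CC(SCCOCCOCCOc2cc(O)c(C(=O)CCc3ccc(O)cc3)c(O)c2)C1=O)OCn1cc(F)c(=O)[nH]c1=O`, 86900 nM in a functional assay on HT-29 cells (Homo sapiens) for cytotoxicity, read by sulforhodamine B assay, with a stated time of 48 h, in the presence of a further agent that is not named here; a higher number here means a weaker inhibitor, a lower number a stronger inhibitor
- compound 2, `O=C(CCCSSCCOCCOCCOc1cc(O)c(C(=O)CCc2ccc(O)cc2)c(O[C@@H]2O[C@H](CO)[C@@H](O)[C@H](O)[C@H]2O)c1)OCn1cc(F)c(=O)[nH]c1=O`, 8000 nM in this assay

Of these two numbers, compound 2 gives the lower one, and the gap to compound 1 is beyond the usual scatter, so compound 2 is the stronger inhibitor of the pair. Compound 1 and compound 2 differ in several places at once, so their gap cannot be tied to any single change.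

Compound 3, `O=C(CCCSSCCOCCOCCOc1cc(O)c(C(=O)CCc2ccc(O)cc2)c(O)c1)OCn1cc(F)c(=O)[nH]c1=O`, is not yet measured. It differs from compound 2 in one place: hydrogen in place of 3,4,5-trihydroxy-6-(hydroxymethyl)oxan-2-yl on an oxygen on an aromatic ring. Within the data shown here, no measured pair shows this change in isolation, so there is no direct guide to its effect. A step of modest size is expected, likely toward a weaker inhibitor, though a result within the scatter would not surprise. For compound 3 in this assay the expected value is 12000 nM, with a range from 3000 nM to 40000 nM, which amounts to an expected step of a 1.5-fold higher number from compound 2 to compound 3 (0.18 log units; within the scatter).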

Compound 3, half-maximal inhibitory concentration: 3800 nM
Compound 3: the middle estimate sits 3.2-fold (0.50 log units) above what was measured, and the stated range covers the measured number.
By their numbers in this assay, from the lowest: compound 3; then compound 2; then compound 1.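

In this assay, replacing the 3,4,5-trihydroxy-6-(hydroxymethyl)oxan-2-yl group on the oxygen on the aromatic ring with hydrogen gives a 2.1-fold lower number from compound 2 to compound 3 (0.32 log units; beyond the scatter), a modest step that lies beyond the scatter. This single-place comparison, which the earlier pair could not provide, shows that this large ring-bearing group is not needed for activity in this assay, since the free hydroxy form is the stronger inhibitor of the pair. Nothing shown here explains the size or direction of this step.

Still open, going by these compounds, is whether a methyl group or an acetyl group on this same oxygen would give a number closer to compound 2 or to compound 3. On these data alone, it is also open whether the same change would have a similar effect with the different linker found in compound 1.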